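Adding a Boc-Protected Amine to an Inactive Core

The source may hold more compounds than are shown below. What is called first, only, known or untested is meant among the compounds shown, and "the series" means these compounds.

Compound 1 `O=[N+]([O-])c1ccc(-c2noc(Cc3c[nH]c4ccccc34)n2)cc1` and compound 2 `COc1cc(-c2noc(-c3ccccc3)n2)cc(OC)c1OC` were tested in a functional assay on cells (Splenocyte, Mus musculus, strain BALB/c) for inhibition, read by scintillation counting and thymidine incorporation, with stated times of 48 h and 8 h; on this read-out lower numbers stand for stronger inhibition and higher numbers for weaker inhibition. Compound 1 gave only a limit of the assay, > 50000 nM. Compound 2 likewise gave only a limit, > 50000 nM. Both values therefore sit at the same place, (the limit of > 50000 nM in this assay, at which 2 of the 2 values shown sit), so neither shows measurable inhibition. Compound 3 `COc1cc(-c2noc(-c3ccc(NC(=O)OC(C)(C)C)cc3)n2)cc(OC)c1OC` differs from compound 2 by (tert-butoxycarbonyl)amino in place of hydrogen on an aromatic carbon. Going by the values given here, with no measured step to lean on, the expected step of an at least 1.2-fold lower number from compound 2 to compound 3 (0.09 log units; that floor lies within the scatter) is small and its direction uncertain. Compound 3 is therefore expected to give about 40000 nM, with a likely range from 10000 nM to 100000 nM.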

Compound 3, half-maximal inhibitory concentration: 1600 nM
Estimate against measurement, compound 3: 25-fold (1.40 log units) above; measured number outside the range, below it.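

In this assay, putting (tert-butoxycarbonyl)amino in place of hydrogen gives an at least 31-fold lower number from compound 2 to compound 3 (1.49 log units; beyond the scatter). This shows that the shared core is not inactive in every form, and that this aromatic carbon, para to a large group, can carry a substituent that brings measurable inhibition. The full size of the step stays unknown, as the starting value is only a limit: the limit of > 50000 nM in this assay, at which 2 of the 3 values shown sit.

On these data alone, what remains open is which part of the new group matters. A free amine or a small acetamide at the same carbon would begin to separate the nitrogen from the tert-butyl ester part.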